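Chloro for bromo: working notes toward compound 3

The source may hold more compounds than are shown below. What is called first, only, known or untested is meant among the compounds shown, and "the series" means these compounds.

Compound 1 `CCC[C@@H](O)C1=C(Br)/C(=C/I)OC1=O`: 0.3 ug/mL
Compound 2 `CCC[C@@H](O)C1=C(Br)/C(=C/Br)OC1=O`: 0.1 ug/mL

Going by the values given here, in a functional assay on KB cells (Homo sapiens) for cytotoxicity (a lower number here means that less compound is needed, a higher number that more compound is needed for the effect), compound 2 stands at the lowest of the two numbers, compound 1 being the only neighbour, separated by a 3.0-fold lower number from compound 1 to compound 2 (0.48 log units; beyond the scatter). Compound 3 `CCC[C@@H](O)C1=C(Br)/C(=C/Cl)OC1=O` differs from compound 2 by chloro in place of bromo on a double-bonded chain carbon bound to a double-bonded ring carbon. Among the compounds with values here, the one measured step, a 3.0-fold lower number from compound 1 to compound 2 (0.48 log units; beyond the scatter), is the only guide: a halogen exchange at the same place gave a modest drop. A further step in the same direction, of similar or smaller size, is expected, a 1.4-fold lower number from compound 2 to compound 3 (0.15 log units; within the scatter). Compound 3 is estimated at 0.07 ug/mL, with a range from 0.03 ug/mL to 0.2 ug/mL.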

Compound 3, concentration for half-maximal effect: 1.4 ug/mL
For compound 3 the middle estimate is 20-fold (1.30 log units) below the measured one, and the stated range ends below it.
By their numbers in this assay, from the lowest: compound 2; then compound 1; then compound 3.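

In this assay the halogen on a double-bonded chain carbon bound to a double-bonded ring carbon does not follow one direction: bromo gives the lowest number of the three, with a 14-fold higher number from compound 2 to compound 3 (1.15 log units; beyond the scatter) and a 4.7-fold higher number from compound 1 to compound 3 (0.67 log units; beyond the scatter). Chloro therefore lies beyond iodo, on the opposite side of bromo, so the step from iodo to bromo does not continue to chloro. No available evidence accounts for this order.

Open, as far as these compounds go, is whether a fluoro or a nitrile at this place would track the bromo or the chloro result. Also open, from the compounds shown here alone, is whether the same halogen order holds on a core carrying a longer chain.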